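This account rests on a few compounds, and the source may have more. Where it says the series, first, only, none or still open, it means among the compounds named here.

Compound 1, `O=C(Nc1ccccc1)C(Cl)Cl`, is the parent of this small set. In a functional assay on KB cells (Homo sapiens) for antiproliferative activity, read by MTT assay, with a stated time of 72 h (a higher number here means a weaker inhibitor, a lower number a stronger inhibitor), compound 1 stands as "not determined" (no result reported): the measurement was not carried out, so no single number describes where it stands. Among the compounds with values here, the only measured member is compound 2, `O=C(Nc1ccccc1Br)C(Cl)Cl`, which in this assay gives 67900 nM, a very weak result that marks the only anchor for the whole series. The account now turns to compound 3, `O=C(Nc1cccc(Br)c1)C(Cl)Cl`, which still awaits testing in this assay. Compound 3 arises from compound 1 through one change, (bromo in place of hydrogen on an aromatic carbon). Within the data shown here, since no pair of measured compounds shows what this change does, there is no step to quote; on the evidence of compound 2 alone, the expectation is that compound 3 will fall in the same weak region rather than show a large shift in either direction, and that any movement would not clearly exceed the usual scatter. Compound 3 is therefore expected to give about 50000 nM in this assay, within a range of 15000 nM to 150000 nM, because compound 2 gives 67900 nM.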

Compound 3, half-maximal inhibitory concentration: 8180 nM
The estimate for compound 3 lay 6.1-fold (0.79 log units) above the measured number; the measured number lies below the stated range.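

No step can be read from compound 1 to compound 3, as compound 1 has no single number in this assay. Going by these compounds, what bromo in place of hydrogen does to the activity of compound 1 therefore stays open. No evidence shown here bears on the result for compound 3.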